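Dimethylsulfamoylethyl replaces sulfamoylamino on a furazan amine

A few compounds are considered here, and "the series" means these few. Any claim that something is new, unique, unknown or untested is made for them only; others in the source may bear on it.

Compound 1 `NS(=O)(=O)NNc1nonc1/C(=N/O)Nc1ccc(F)c(Br)c1` gives 218 nM in an assay on isolated protein for inhibition of Indoleamine 2,3-dioxygenase 1 (Homo sapiens), read by fluorescence, with a stated time of 60 min; a higher number here means a weaker inhibitor, a lower number a stronger inhibitor.
Compound 2 `[O-][S+]1CC(Nc2nonc2/C(=N/O)Nc2ccc(F)c(Br)c2)C1` gives 212 nM in this assay.
Compound 3 `NS(=O)(=O)CCNc1nonc1/C(=N/O)Nc1ccc(F)c(Br)c1` gives 71 nM in this assay.

Among these three numbers compound 1 has the highest, though compound 2 sits beside it: a 1.0-fold lower number from compound 1 to compound 2 (0.01 log units; within the scatter). Compound 3 lies further off: a 3.1-fold lower number from compound 1 to compound 3 (0.49 log units; beyond the scatter), and a 3.0-fold lower number from compound 2 to compound 3 (0.48 log units; beyond the scatter).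

Compound 4 `CN(C)S(=O)(=O)CCNc1nonc1/C(=N/O)Nc1ccc(F)c(Br)c1` has not been measured. It differs from compound 1 in one place: 2-(dimethylsulfamoyl)ethyl in place of sulfamoylamino on a nitrogen on an aromatic ring. Going by the values given here, the change shares with the step from compound 1 to compound 3 the replacement of the sulfamoylamino by a sulfamoyl-bearing two-carbon chain, and that step lowered the number modestly; it adds to this the two methyl groups on the sulfamoyl nitrogen, for which no measured pair gives any guidance. The step from compound 1 to compound 4 in this assay is therefore expected to be downward, about the size seen for compound 3, with a wider margin for the untested methylation: a 2.2-fold lower number from compound 1 to compound 4 (0.34 log units; beyond the scatter). Compound 4 is estimated at 100 nM, with a range from 35 nM to 300 nM.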

Compound 4, half-maximal inhibitory concentration: 105 nM
Estimate against measurement, compound 4: 1.1-fold (0.02 log units) below, and the stated range covers the measured number.
By their numbers in this assay, from the lowest: compounds 3 and 4 (each within the scatter of the next); then compounds 2 and 1 (each within the scatter of the next).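

In this assay, the two-carbon chain keeps its advantage when its sulfamoyl nitrogen carries two methyl groups: a 2.1-fold lower number from compound 1 to compound 4 (0.32 log units; beyond the scatter), and a 2.0-fold lower number from compound 2 to compound 4 (0.31 log units; beyond the scatter). Dimethylamino in place of amino on the sulfonyl sulfur stays within the scatter, a 1.5-fold higher number from compound 3 to compound 4 (0.17 log units; within the scatter), so at this position a group with 0 hydrogen-bond donors reads no differently from the amino compound. No measurement at hand bears on what lies behind these steps.

The compounds shown leave open whether a single methyl on the sulfamoyl nitrogen, or a larger group such as isopropyl, would read the same. They also leave open whether a longer chain on the nitrogen, or a carboxylic acid at the end of the chain in place of the sulfamoyl group, would hold the lower number.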